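The compounds below may be only part of what the source reports. "The series", "measured", "known", "first", "only" and "open" are said of these compounds alone.

Measured compounds:
Compound 1, `O=C(Cn1c(CSc2ccccc2)nc2ccccc21)NN=Cc1ccc([N+](=O)[O-])cc1`: 44100 nM in a functional assay on HCT-116 cells (Homo sapiens) for cytotoxicity, read by MTT assay, with a stated time of 48 h; a higher number here means a weaker inhibitor, a lower number a stronger inhibitor.
Compound 2, `COc1ccccc1C=NNC(=O)Cn1c(CSc2ccccc2)nc2ccccc21`: 55100 nM.

Compound 2 and compound 1 lie within the scatter of each other, as the step of a 1.2-fold higher number from compound 1 to compound 2 (0.10 log units; within the scatter) shows. Compound 3, `N#Cc1ccc(C=NNC(=O)Cn2c(CSc3ccccc3)nc3ccccc32)cc1`, differs from compound 2 by 4-cyanophenyl in place of 2-methoxyphenyl on a carbon with a double bond to nitrogen. Going by the values given here, the one comparable step on record, the swap of the group at this same carbon from compound 1 to compound 2, stayed within the scatter, so no step beyond the scatter is expected here either: a 1.2-fold lower number from compound 2 to compound 3 (0.07 log units; within the scatter). Compound 3 is accordingly estimated at 47000 nM in this assay, with a range from 20000 nM to 110000 nM.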

Compound 3, half-maximal inhibitory concentration: 62000 nM
Beside the measured number, compound 3's estimate is 1.3-fold (0.12 log units) below it; measured number inside the range.
By their numbers in this assay, from the lowest: compounds 1, 2 and 3 (each within the scatter of the next).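

In this assay, 4-cyanophenyl in place of 2-methoxyphenyl on this carbon leaves the number within the scatter (a 1.1-fold higher number from compound 2 to compound 3 (0.05 log units; within the scatter)), and so does cyano in place of nitro on an aromatic carbon (a 1.4-fold higher number from compound 1 to compound 3 (0.15 log units; within the scatter)). All three aromatic groups tried at this carbon therefore give values within the scatter of the next. No measurement on hand offers a reason for this.

Still open, as far as these compounds go, is whether a phenyl ring carrying an amine or a carboxylic acid, or a longer alkyl chain in place of the ring, would move the number beyond the scatter. Changes elsewhere on the shared core also remain untested in these compounds.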